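Swapping an anilino group for a dialkylamino on a quinone core

The source may hold more compounds than are shown below. What is called first, only, known or untested is meant among the compounds shown, and "the series" means these compounds.

Compound 1 `O=C1C(Nc2ccc(I)cc2)=CC(=O)c2c1nc1n2[C@H]2OC[C@@H](O)[C@H]2OC1` gives 2150 nM in a functional assay on MGC-803 cells (Homo sapiens) for inhibition, read by sulforhodamine B assay; a higher number here means a weaker inhibitor, a lower number a stronger inhibitor.
Compound 2 `O=C1C=C(NCc2ccccc2)C(=O)c2c1nc1n2[C@H]2OC[C@@H](O)[C@H]2OC1` gives 2670 nM in this assay.
Compound 3 `CCc1ccc(NC2=CC(=O)c3nc4n(c3C2=O)[C@H]2OC[C@@H](O)[C@H]2OC4)cc1` gives 1290 nM in this assay.

Compound 1 stands second highest of the three numbers, within the scatter of both neighbours: compound 2 is close above it and compound 3 is somewhat below it, so no ordering among these three can be drawn. Among the measured compounds shown here, the one step that differs in a single place, a 2.1-fold lower number from compound 2 to compound 3 (0.32 log units; beyond the scatter), is the only measured change at the amine nitrogen, and it is modest.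

Compound 4 `CCCN(CCC)C1=CC(=O)c2c(nc3n2[C@H]2OC[C@@H](O)[C@H]2OC3)C1=O` differs from compound 1 in this way: dipropylamino in place of (4-iodophenyl)amino on a double-bonded ring carbon. For the measured compounds named here, no measured step covers the loss of the aromatic ring and the hydrogen-bond donor together; the step from compound 2 to compound 3 shows only that changing the group on the nitrogen moves the number a little. The account therefore expects a weakening beyond the scatter, of about a 2.1-fold higher number from compound 1 to compound 4 (0.32 log units; beyond the scatter). Compound 4 is estimated at 4500 nM, with a range from 1500 nM to 13000 nM.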

Compound 4, half-maximal inhibitory concentration: > 16000 nM
Compound 4: no number, only a limit; the forecaster's own chance of this, stated with the estimate: 10%; middle value at least 3.5-fold (0.55 log units) from the limit.
By their numbers in this assay, from the lowest: compounds 3, 1 and 2 (each within the scatter of the next, the first and the last beyond it). At a limit, above all of these: compound 4.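

Compound 4 stands at a limit and not at a number: the limit of > 16000 nM in this assay, at which 1 of the 4 values shown sits. Among the compounds shown here, the change to dipropylamino in place of (4-iodophenyl)amino on a double-bonded ring carbon gives an at least 7.4-fold higher number from compound 1 to compound 4 (0.87 log units; beyond the scatter), whereas the only earlier step that changed the group on an amine nitrogen, a 2.1-fold lower number from compound 2 to compound 3 (0.32 log units; beyond the scatter), was modest. So the group on this ring carbon can matter much more than compounds 1, 2 and 3 suggested, all three of which carry an aromatic ring and an amine hydrogen that compound 4 lacks.

This single step removes the ring and the hydrogen-bond donor together, so the compounds shown leave open which of the two loses the activity. Propylamino, which keeps the amine hydrogen without the ring, and N-methyl-4-iodoanilino, which keeps the ring without that hydrogen, would separate them.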